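The source may report more compounds than this note shows. Statements on the series, on what has been measured and on what is new or still open speak of the compounds shown alone.

Working notes on the series

Compound 1 `Clc1ccc(Nc2nnc(-c3ccccc3)s2)cc1Cl` gives 6280 nM in an assay on isolated protein for inhibition of beta-glucuronidase (Bos taurus), read by spectrophotometry, with a stated time of 30 min; on this read-out higher numbers stand for weaker inhibition and lower numbers for stronger inhibition. Compound 2 `COc1ccc(-c2nnc(Nc3ccc(Cl)c(Cl)c3)s2)cc1` carries the change methoxy in place of hydrogen on an aromatic carbon relative to compound 1, and in this assay compound 2 gives 4160 nM. The step of a 1.5-fold lower number from compound 1 to compound 2 (0.18 log units; within the scatter) is small.

Compound 3 `COc1ccccc1-c1nnc(Nc2ccc(C)cc2)s1` rests on a different core; the difference between the core of compound 3 and the core of compound 1 is not broken down here. In this assay compound 3 gives 58100 nM, the highest number of the three measured compounds, with compound 1 nearest and compound 2 furthest, both separated from it by more than the scatter.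

Compound 4 `COc1ccc(-c2nnc(Nc3ccc(C)cc3)s2)c(OC)c1` is not yet measured. It differs from compound 3 by methoxy in place of hydrogen on an aromatic carbon. This is the same kind of change as that from compound 1 to compound 2, not the same one: in compound 4 the entering methoxy sits meta to a methoxy group (2 heavy atoms) as well as para to a large group, whereas in compound 2 the surroundings of the entering group are described only as para to a large group.

Within the data shown here, with only one earlier instance of this kind of change available, the expected step of a 1.4-fold lower number from compound 3 to compound 4 (0.14 log units; within the scatter) in this assay is taken to be of the same small size as a 1.5-fold lower number from compound 1 to compound 2 (0.18 log units; within the scatter), and is expected to lie within the scatter. On that basis compound 4 is expected to give about 42000 nM, with a plausible range from 14000 nM to 130000 nM.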

Compound 4, half-maximal inhibitory concentration: 39300 nM
Beside the measured number, compound 4's estimate is 1.1-fold (0.03 log units) above it; low and high end bracket the measured number.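

In this assay the new step is a 1.5-fold lower number from compound 3 to compound 4 (0.17 log units; within the scatter), and it matches the earlier step closely. Methoxy in place of hydrogen on an aromatic carbon therefore gives steps of the same small size on the two cores, even though in compound 4 the entering methoxy sits meta to a methoxy group as well as para to a large group: the same change on two cores in this assay, a 1.5-fold lower number (0.18 log units; within the scatter) from compound 1 to compound 2 and a 1.5-fold lower number (0.17 log units; within the scatter) from compound 3 to compound 4, 1.0-fold (0.01 log units) apart, within the scatter of two such steps. Among these compounds, this shows only that the change carries over between these two cores without a step beyond the scatter; since both steps lie within the scatter, neither compound 2 nor compound 4 can be told apart from its partner, and two pairs support no general rule for the series.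

The compounds shown leave open whether any other group at this place, such as an amine or a carboxylic acid, would give a step beyond the scatter on either core. They also leave open which structural difference lies behind the higher number of compound 3 compared with compound 1, as these two compounds differ in more than one place and no single change can be isolated between them.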